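The compounds below may be only part of what the source reports. "The series", "measured", "known", "first", "only" and "open" are said of these compounds alone.

In a physicochemical assay for lipophilicity, in phosphate buffer, measured as octanol-water partition, with a stated time of 24 h (a higher number here means a more lipophilic compound, a lower number a more polar compound), the three measured compounds stand as follows:

compound 1, `Fc1ccc(Oc2ccc(/C=N/NC(=S)Nc3ccc(Br)cc3)cc2)cc1`: 5.82
compound 2, `Fc1ccc(NC(=S)N/N=C/c2ccc(Oc3ccc(F)cc3)cc2)cc1`: 5.19
compound 3, `Fc1ccc(Oc2ccc(/C=N/NC(=S)Nc3ccccc3)cc2)cc1`: 5.09

Compound 1 gives the highest of the three numbers in this assay; compound 2 lies a number 0.63 log units lower from compound 1 to compound 2 (beyond the scatter) and compound 3 lies a number 0.73 log units lower from compound 1 to compound 3 (beyond the scatter), both beyond the scatter. Compound 4, `S=C(N/N=C/c1ccc(Oc2ccc(Cl)cc2)cc1)Nc1ccc(Br)cc1`, is reached from compound 1 by a single change: chloro in place of fluoro on an aromatic carbon, on an aromatic carbon of a six-membered aromatic ring of carbon only, para to a large group.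

For the measured compounds named here, no measured step exchanges fluoro for chloro. Going by the values given here, the steps that bear on it are halogen changes on the other outer ring: the bromo-to-fluoro step a number 0.63 log units lower from compound 1 to compound 2 (beyond the scatter) and the bromo-to-hydrogen step a number 0.73 log units lower from compound 1 to compound 3 (beyond the scatter), while the fluoro-to-hydrogen step a number 0.10 log units lower from compound 2 to compound 3 (within the scatter) stays within the scatter. Fluoro and hydrogen thus read alike, and the heavier bromo reads markedly higher. Chloro stands between fluoro and bromo in that series, so a modest rise beyond the scatter is expected, estimated as a number 0.48 log units higher from compound 1 to compound 4 (beyond the scatter). Compound 4 is therefore expected to give about 6.3, with a range from 5.9 to 6.75.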

Compound 4, partition coefficient: 6.24
Compound 4: middle estimate off by 0.06 log units, on the high side, and the stated range covers the measured number.
By their numbers in this assay, from the lowest: compounds 3 and 2 (each within the scatter of the next); then compound 1; then compound 4.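

In this assay, chloro in place of fluoro on the phenoxy ring gives a number 0.42 log units higher from compound 1 to compound 4 (beyond the scatter). For the compounds shown here, the earlier steps all changed the substituent on the other outer ring, so this is the first sign that the number also responds to a change at this place, on an aromatic carbon para to a large group, and that a halogen exchange here alone carries it beyond the scatter. No measurement shown here accounts for this rise.

The compounds shown leave open how an amine, a carboxylic acid or a methoxy group would read at this place, and whether bromo here would take the number further. They also leave open whether the same exchange of fluoro for chloro gives a similar step when the other outer ring carries hydrogen instead of bromo.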